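Moving a chlorine around an imine-linked phenyl ring

The compounds below may be only part of what the source reports. "The series", "measured", "known", "first", "only" and "open" are said of these compounds alone.

Measured compounds, with their values in an ADME assay on cells (Rhabdomyosarcoma cell, Homo sapiens) for cytotoxicity, read by MTT assay, with a stated time of 72 h; on this read-out higher numbers stand for lower toxicity in this test and lower numbers for higher toxicity in this test:
compound 1 `Nc1sc2c(c1-c1nc3cc(Cl)ccc3s1)CCC2`: 59.1 ug/mL
compound 2 `Fc1ccc(/C=N/c2sc3c(c2-c2nc4ccccc4s2)CCC3)cc1`: 290 ug/mL
compound 3 `Clc1ccc(/C=N/c2sc3c(c2-c2nc4ccccc4s2)CCCC3)cc1`: 367 ug/mL

Among these three numbers compound 3 stands highest. Compound 2 sits close to it, within the usual scatter of repeated measurements, so no order between compounds 2 and 3 can be read from these two values. Compound 1, which carries a free amine instead of an imine-linked phenyl ring, gives a number that lies below that of compound 3 by more than the scatter.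

Compound 4 `Clc1ccccc1/C=N/c1sc2c(c1-c1nc3ccccc3s1)CCCC2` is the next compound in this series. It differs from compound 3 in one place: 2-chlorophenyl in place of 4-chlorophenyl on a carbon with a double bond to nitrogen. The chlorine atom thus changes its position on the same ring while everything else stays as it is.

Among the measured compounds shown here, no pair of measured compounds shows what such a move does in this assay. With no guide from the data, the step from compound 3 to compound 4 is expected to be small, in no particular direction, and not beyond the scatter: a 1.1-fold lower number from compound 3 to compound 4 (0.05 log units; within the scatter). Compound 4 is therefore estimated to give 330 ug/mL, with a range from 150 ug/mL to 700 ug/mL.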

Compound 4, half-maximal cytotoxic concentration: 332 ug/mL
Compound 4: the middle estimate sits 1.0-fold (0.00 log units) below what was measured; low and high end bracket the measured number.
By their numbers in this assay, from the lowest: compound 1; then compounds 2, 4 and 3 (each within the scatter of the next).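

In this assay, among the compounds shown here, the chlorine moves from 4-chlorophenyl to 2-chlorophenyl, on the carbon with a double bond to nitrogen, and this gives the first step that isolates such a move (a 1.1-fold lower number from compound 3 to compound 4 (0.04 log units; within the scatter)). The two placements of the chlorine therefore cannot be told apart in this test, at least for compound 3 and compound 4. No measurement available here offers an explanation for this result.

On these data alone, it remains open whether a different group on this ring, such as a methoxy group, a nitrile or an amine, would also leave the number within the scatter of compound 3. It is also unknown whether the same kind of move, such as 2-fluorophenyl in place of 4-fluorophenyl, would behave alike on the core of compound 2.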